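Ester series: aryl methyl for chloro, cytotoxicity outlook

The compounds below may be only part of what the source reports. "The series", "measured", "known", "first", "only" and "open" are said of these compounds alone.

Compound 1 `CCOC(=O)c1c(C)oc2ncnc(Nc3cccc(Cl)c3)c12` gives > 1000000 nM in a functional assay on MCF7 cells (Homo sapiens) for cytotoxicity, read by MTT assay, with a stated time of 72 h; on this read-out higher numbers stand for weaker inhibition and lower numbers for stronger inhibition.
Compound 2 `Cc1oc2ncnc(Nc3cccc(Cl)c3)c2c1C(=O)NC(C)C` gives 191000 nM in this assay.
Compound 3 `Cc1cccc(Nc2ncnc3oc(C)c(CO)c23)c1` gives 17000 nM in this assay.

Compound 1 stands at the limit of > 1000000 nM in this assay, at which 1 of the 3 values shown sits; its value is a limit of the assay and not a number. Compound 2 gives 191000 nM, and the step of an at least 5.2-fold lower number from compound 1 to compound 2 (0.71 log units; beyond the scatter) shows that the isopropylamino in place of ethoxy on the carbonyl carbon is enough to bring a number inside the measured range. Within the data shown here, compound 3 gives 17000 nM; it carries 3-methylphenyl together with a hydroxymethyl on the core, and no single-change step joins it to compound 1 or compound 2, so its value is taken on its own.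

Compound 4 `CCOC(=O)c1c(C)oc2ncnc(Nc3cccc(C)c3)c12` differs from compound 1 by methyl in place of chloro on an aromatic carbon. Among the measured compounds shown here, no measured step touches this change; the one measured step concerns the carbonyl substituent only. With the ester kept and compound 1 at the limit, the step of an at least 1.1-fold lower number from compound 1 to compound 4 (0.04 log units; that floor lies within the scatter) is expected to be none beyond the scatter, and a limit rather than a number is thought likely. Compound 4 is therefore estimated at 900000 nM in this assay, with a range from 200000 nM to 4000000 nM.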

Compound 4, half-maximal inhibitory concentration: > 1000000 nM
Compound 4: a limit, no number; the forecaster's own chance of this, stated with the estimate: 60%; middle value at least 1.1-fold (0.04 log units) from the limit.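

In this assay compound 4 gives > 1000000 nM, which is a limit of the assay and not a number. With the ethoxycarbonyl kept, methyl in place of chloro on the aromatic carbon does not bring a number into the measured range, and the step between the two ester compounds cannot be read: the limit of > 1000000 nM in this assay, at which 2 of the 4 values shown sit.

Among these compounds, with 3-methylphenyl held, ethoxycarbonyl in place of hydroxymethyl on an aromatic carbon gives an at least 58-fold higher number from compound 3 to compound 4 (1.76 log units; beyond the scatter), which is the first single-change link for the hydroxymethyl compound and shows a large step from the group on the core, whereas the aryl change shows nothing readable in the ester series.

Going by these compounds, whether chloro and methyl differ at all on this aromatic carbon remains open, and the question could only be read with a core group that keeps both values inside the measured range. Also open, on these data alone, is where a carboxylic acid or an aminomethyl group in place of the ethoxycarbonyl would fall, with 3-methylphenyl held, relative to the hydroxymethyl value.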